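The source may report more compounds than this note shows. Statements on the series, on what has been measured and on what is new or still open speak of the compounds shown alone.

Three compounds here share one core. Compound 1 `O=S(=O)(c1ccc(F)cc1)c1cnc2cc(F)c(Cl)cc2c1-c1ccc(Cl)cc1` gives 0.34 mL/min in an ADME assay on microsomes from liver (Rattus norvegicus) for metabolic stability, tested at 2.5 uM; on this read-out higher numbers stand for fast clearance and lower numbers for slow clearance. Compound 2 `O=S(=O)(c1cc(Cl)cc(Cl)c1)c1cnc2cc(F)ccc2c1-c1ccc(Cl)cc1` gives 0.77 mL/min in this assay, and compound 3 `O=S(=O)(c1ccc(F)c(F)c1)c1cnc2cc(F)ccc2c1-c1ccc(Cl)cc1` gives 1.41 mL/min in this assay. Compound 3 thus holds the highest of the three numbers, though its gap to compound 2 lies within the scatter; only compound 1 stands clearly lower. Compound 4 `O=S(=O)(c1ccc(F)cc1)c1cnc2cc(F)ccc2c1-c1ccc(Cl)cc1` differs from compound 3 by hydrogen in place of fluoro on an aromatic carbon. For the measured compounds named here, the one measured step on the sulfonyl aryl group, a 1.8-fold higher number from compound 2 to compound 3 (0.26 log units; within the scatter), was small, and compound 1 carries the same 4-fluorophenyl group but differs elsewhere as well, so its lower number gives no firm guide. For compound 4 the expected change is therefore small, a 1.4-fold lower number from compound 3 to compound 4 (0.15 log units; within the scatter), possibly slightly downward. Compound 4 is estimated at 1 mL/min, between 0.45 mL/min and 2.2 mL/min.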

Compound 4, intrinsic clearance in a liver preparation (reported as CLH), per the amount of preparation that the assay uses: 0.89 mL/min
Compound 4: the middle estimate sits 1.1-fold (0.05 log units) above what was measured; the range from low to high includes it.
By their numbers in this assay, from the lowest: compound 1; then compounds 2, 4 and 3 (each within the scatter of the next).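

In this assay the change from 3,4-difluorophenyl to 4-fluorophenyl gives only a small shift (a 1.6-fold lower number from compound 3 to compound 4 (0.20 log units; within the scatter)), and 4-fluorophenyl in place of 3,5-dichlorophenyl also stays small (a 1.2-fold higher number from compound 2 to compound 4 (0.06 log units; within the scatter)). All three sulfonyl aryl groups thus lie within the scatter of one another, whereas hydrogen in place of chloro on the core goes beyond it (a 2.6-fold higher number from compound 1 to compound 4 (0.42 log units; beyond the scatter)). No measurement here offers an explanation for these results.
On these data alone, it remains open whether an amine or a carboxylic acid on the sulfonyl aryl ring would move the number beyond the scatter.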